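Difluorocyclopentyl to difluorocyclohexyl on the shared core

This account rests on a few compounds, and the source may have more. Where it says the series, first, only, none or still open, it means among the compounds named here.

In a physicochemical assay for solubility, using the shake flask method, in simulated intestinal fluid, measured as kinetic solubility, with a stated time of 20 h, at pH 6.5 (a higher number here means a more soluble compound, a lower number a less soluble compound), compound 1 (`NC(=O)c1ccc(Nc2cc3[nH]c(-c4cccc(C(F)(F)F)c4)nc3cn2)nc1`) gives < 5000 nM as a limit of the assay and not as a number. Among the measured compounds shown here, compound 2 (`FC1(F)CCC(c2nc3cnc(Nc4ccc(C(F)(F)F)cn4)cc3[nH]2)C1`) reads 163000 nM there and holds the only actual number so far, which makes it the single anchor for the next step.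

Compound 3 (`FC1(F)CCC(c2nc3cnc(Nc4ccc(C(F)(F)F)cn4)cc3[nH]2)CC1`) keeps the core of compound 2 and carries 4,4-difluorocyclohexyl in place of 3,3-difluorocyclopentyl on an aromatic carbon. The counted difference is 4,4-difluorocyclohexyl in place of 3,3-difluorocyclopentyl on an aromatic carbon and nothing else changes.

For the measured compounds named here, no measured pair shows what a change of this kind does in this assay so the expectation rests on the structural change and on compound 2 at 163000 nM alone. A small downward move is expected, of a size that may stay within the usual scatter. The expected move is a 1.5-fold lower number from compound 2 to compound 3 (0.17 log units; within the scatter) on this estimate. Compound 3 is estimated at 110000 nM with an expected range from 40000 nM to 250000 nM in this assay as the working figure.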

Compound 3, solubility: 93000 nM
For compound 3 the middle estimate is 1.2-fold (0.07 log units) above the measured one, within the range that was stated.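

At this position, on an aromatic carbon of a five-membered aromatic ring with 2 nitrogen, between two ring nitrogen atoms, 4,4-difluorocyclohexyl in place of 3,3-difluorocyclopentyl gives a 1.8-fold lower number from compound 2 to compound 3 (0.24 log units; within the scatter) in this assay. On this one pair, the scatter does not separate the two rings, so this read-out gives no ground for preferring either group on the shared core. Compound 2 and compound 3 both give numbers, which makes this the first step in the series that can be read at all, and neither sits at the one limit shown: the limit of < 5000 nM in this assay, at which 1 of the 3 values shown sits.

As far as these compounds go, what an unsubstituted cyclohexyl, a piperidine amine or a carboxylic acid would read at this position in this assay stays open, and with it whether anything placed here can move the number beyond the scatter. A single pair also cannot tell whether the same exchange of rings would read alike with a different group at the other end of the shared core.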